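The source may report more compounds than this note shows. Statements on the series, on what has been measured and on what is new or still open speak of the compounds shown alone.

In a functional assay on MCF7 cells (Homo sapiens) for inhibition, read by MTT assay, with a stated time of 72 h (a higher number here means a weaker inhibitor, a lower number a stronger inhibitor), compound 1 (`FC(F)(F)c1ccc(CSc2nc(N3CCNCC3)cc(C(F)(F)F)n2)cc1`) gives 10700 nM and compound 2 (`CN1CCN(c2cc(C(F)(F)F)nc(SCc3ccc(C(F)(F)F)cc3)n2)CC1`) gives 30200 nM as the higher of the two numbers. Compound 3 (`CCN1CCN(c2cc(C(F)(F)F)nc(SCc3ccc(C(F)(F)F)cc3)n2)CC1`) differs from compound 2 by one change (methyl in place of hydrogen on a saturated chain carbon bound to an amine nitrogen in a ring), methyl in place of hydrogen on a saturated chain carbon bound to an amine nitrogen in a ring, so methyl becomes ethyl. Among the measured compounds shown here, the only measured step bearing on this (a 2.8-fold higher number from compound 1 to compound 2 (0.45 log units; beyond the scatter)) was modest and sits on the amine nitrogen itself. A further small rise, not beyond the scatter, is therefore expected (a 1.2-fold higher number from compound 2 to compound 3 (0.08 log units; within the scatter)) as the estimated step. Compound 3 is estimated at 36000 nM with an expected range of 15000 nM to 80000 nM in this assay.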

Compound 3, half-maximal inhibitory concentration: 22000 nM
Compound 3: the middle estimate sits 1.6-fold (0.21 log units) above what was measured, within the range that was stated.
By their numbers in this assay, from the lowest: compound 1; then compounds 3 and 2 (each within the scatter of the next).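

Going from 4-methylpiperazin-1-yl to 4-ethylpiperazin-1-yl gives a 1.4-fold lower number from compound 2 to compound 3 (0.14 log units; within the scatter) in this assay, so on this saturated chain carbon the added methyl produces no change that can be told from the scatter. Ethyl in place of hydrogen on the amine nitrogen in the ring gives a 2.1-fold higher number from compound 1 to compound 3 (0.31 log units; beyond the scatter) and thus stands on the same side of compound 1 as methyl does. Nothing shown accounts for either step.

The compounds shown leave open whether a longer chain such as propyl on that nitrogen would stay with compound 2 and compound 3. They also leave open whether a carboxylic acid there would return the number towards compound 1.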